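The source may hold more compounds than are shown below. What is called first, only, known or untested is meant among the compounds shown, and "the series" means these compounds.

The measured compounds, with their results in an ADME assay on CCRF-CEM cells (Homo sapiens) for antiproliferative activity, with a stated time of 48 h; a lower number here means a stronger inhibitor, a higher number a weaker inhibitor:

Compound 1, `C=C(Br)C(=O)Nc1ccc(/C=C/C(=O)c2cc(OC)c(OC)c(OC)c2)cc1`, gives 1100 nM.
Compound 2, `C=C(Br)C(=O)Nc1ccc(C(=O)/C=C/c2ccccc2)cc1`, gives 1500 nM.
Compound 3, `COc1cc(C(=O)/C=C/c2ccc(N)cc2)cc(OC)c1OC`, gives 2500 nM.

Compound 1 and compound 3 share a core and differ in one place:

hydrogen in place of (1-bromoethenyl)carbonyl on a nitrogen on an aromatic ring

This single change made the step of a 2.3-fold higher number from compound 1 to compound 3 (0.36 log units; beyond the scatter), a modest weakening that still lies beyond the usual scatter. Compound 2 stands between the other two in number, within the scatter of both, so no order among compound 1, compound 2 and compound 3 can be read from these values alone. How the core of compound 2 differs from the core of compound 1 is not broken down here.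

The unmeasured compound 4, `Nc1ccc(C(=O)/C=C/c2ccccc2)cc1`, is related to compound 2 exactly as compound 3 is related to compound 1:

hydrogen in place of (1-bromoethenyl)carbonyl on a nitrogen on an aromatic ring

The surroundings of the change are the same in both pairs, so this is the same change on a different core. Going by the values given here, the only guide to its effect is the single step seen from compound 1 to compound 3, and because that step is a 2.3-fold higher number from compound 1 to compound 3 (0.36 log units; beyond the scatter), a similar weakening is expected here; compound 4 is estimated to sit at a step of a 2.3-fold higher number from compound 2 to compound 4 (0.36 log units; beyond the scatter). Compound 4 is therefore expected to give about 3400 nM in this assay, most likely between 1500 nM and 8000 nM.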

Compound 4, half-maximal inhibitory concentration: 8500 nM
The estimate for compound 4 lay 2.5-fold (0.40 log units) below the measured number; measured number outside the range, above it.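

In this assay, putting hydrogen in place of the (1-bromoethenyl)carbonyl on the nitrogen gives a 5.7-fold higher number from compound 2 to compound 4 (0.75 log units; beyond the scatter), so on this second core the change again weakens the compound, as it did on the first. Set beside the earlier step, the size of the effect cannot be told apart between the two cores: the same change on two cores in this assay, a 2.3-fold higher number (0.36 log units; beyond the scatter) from compound 1 to compound 3 and a 5.7-fold higher number (0.75 log units; beyond the scatter) from compound 2 to compound 4, 2.5-fold (0.40 log units) apart, within the scatter of two such steps. Going by these compounds alone, this shows that the change went the same way on both cores and that one step is a fair, though rough, guide to the other, but with only two pairs it does not show that the size is fixed, that the same would hold on a third core, or why the group matters.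

The compounds shown leave open which part of the (1-bromoethenyl)carbonyl goes with the lower number, as the whole group leaves in a single change in both pairs. A plain acetyl group or a propenoyl group on the same nitrogen, set on both cores, would help separate the contribution of the carbonyl from those of the double bond and the bromine.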